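The source may hold more compounds than are shown below. What is called first, only, known or untested is meant among the compounds shown, and "the series" means these compounds.

Compound 1 `CCOC(=O)c1c(C)noc1OCC(=O)[C@H](CC(=O)O)NC(=O)[C@@H](NC(=O)COc1cccc2ccccc12)C(C)C` is the reference of the series. In a functional assay on Jurkat cells (Homo sapiens) for inhibition (a higher number here means a weaker inhibitor, a lower number a stronger inhibitor), compound 1 gives only a limit, > 200000 nM (the limit of > 200000 nM in this assay, at which 1 of the 3 values shown sits), so its position on the numbers is known just as a floor. Compound 2 `CC(C)[C@H](NC(=O)COc1cccc2ccccc12)C(=O)N[C@@H](CC(=O)O)C(=O)CSc1nc(-c2ccccc2)no1` gives 102000 nM in this assay and compound 3 `CC(C)[C@H](NC(=O)COc1cccc2ccccc12)C(=O)N[C@@H](CC(=O)O)C(=O)CSc1nnc(-c2ccccc2)o1` gives 150000 nM. Both came from compound 1 by a heteroaryl-sulfanyl group replacing the same side group: an at least 1.9-fold lower number from compound 1 to compound 2 (0.29 log units; that floor lies within the scatter) and an at least 1.3-fold lower number from compound 1 to compound 3 (0.12 log units; that floor lies within the scatter); between them, a 1.5-fold higher number from compound 2 to compound 3 (0.17 log units; within the scatter). Compound 4 `CC(C)[C@H](NC(=O)COc1cccc2ccccc12)C(=O)N[C@@H](CC(=O)O)C(=O)CSc1nnnn1C` carries a further variant of that exchange: (1-methyl-1H-tetrazol-5-yl)sulfanyl in place of (4-(ethoxycarbonyl)-3-methyl-1,2-oxazol-5-yl)oxy on a saturated chain carbon bound to a carbonyl carbon. The two measured steps of this kind bear on it and were small, so a similarly modest move toward a weaker-than-limit number is expected, an at least 1.3-fold lower number from compound 1 to compound 4 (0.12 log units; that floor lies within the scatter). For compound 4 the estimate is 150000 nM, within 50000 nM to 400000 nM.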

Compound 4, half-maximal inhibitory concentration: > 200000 nM
Compound 4 was reported as a limit; the forecaster's own chance of this, stated with the estimate: 40%; middle value at least 1.3-fold (0.12 log units) from the limit.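

Compound 4 gives only a limit in this assay, > 200000 nM, and it is the second compound of the series to do so: the limit of > 200000 nM in this assay, at which 2 of the 4 values shown sit.

Placing the 1-methyl-1H-tetrazol-5-yl group on the sulfur gives an at least 1.3-fold higher number from compound 3 to compound 4 (0.12 log units; that floor lies within the scatter) and an at least 1.9-fold higher number from compound 2 to compound 4 (0.29 log units; that floor lies within the scatter), while the step between compound 1 and compound 4 cannot be read. A sulfanyl link alone therefore does not secure a readable number; among the sulfanyl compounds, only compound 2 and compound 3, both carrying a phenyl, give one.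

From the compounds shown here alone, it remains open whether a 1-phenyl-1H-tetrazol-5-yl group on the sulfur would give a readable number in this assay. That would separate the phenyl from the change of ring.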